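Naphthalen-1-yl to phenyl on the enone chain

This account rests on a few compounds, and the source may have more. Where it says the series, first, only, none or still open, it means among the compounds named here.

In a functional assay on HCT-116 cells (Homo sapiens) for inhibition, read by sulforhodamine B assay, with a stated time of 48 h, tested at 50 uM (a higher number here means more inhibition of growth at the concentration tested, a lower number less inhibition of growth), compound 1 `COc1cc(/C=C/C(=O)/C=C/c2cccc3ccccc23)ccc1OCc1cn(CCOc2cc(=O)oc3ccccc23)nn1` gives 83%, while compound 2 `COc1cccc(/C=C/C(=O)/C=C/c2ccc(OCc3cn(CCCOc4cc(=O)oc5ccccc45)nn3)c(OC)c2)c1` gives 55%. Compound 1 therefore holds the higher of the two numbers, with a gap beyond the usual scatter. Going by the values given here, no measured pair differs in one place only, so no measured step guides the next comparison.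

Compound 3 `COc1cc(/C=C/C(=O)/C=C/c2ccccc2)ccc1OCc1cn(CCOc2cc(=O)oc3ccccc23)nn1` follows from compound 1 through one change phenyl in place of naphthalen-1-yl on a double-bonded chain carbon bound to a double-bonded chain carbon. The rest of the structure stays the same.

A fall somewhat beyond the scatter is expected in this assay, since compound 1 at 83% is the higher reading so far. The expected change is a number 15 percentage points lower from compound 1 to compound 3 (beyond the scatter). For compound 3, the estimated value is 68%, within an expected range of 45% to 85%.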

Compound 3, percent growth inhibition at one concentration: 56%
Beside the measured number, compound 3's estimate is 12 percentage points above it, within the range that was stated.
By their numbers in this assay, from the lowest: compounds 2 and 3 (each within the scatter of the next); then compound 1.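

In this assay, going by these compounds alone, the step of a number 27 percentage points lower from compound 1 to compound 3 (beyond the scatter) is the first reading of a single change, and it shows that the group at this place, on a double-bonded chain carbon bound to a double-bonded chain carbon, affects growth inhibition with the rest of the structure held constant. Naphthalen-1-yl has two six-membered aromatic rings of carbon only and phenyl has one, so the higher reading goes with the larger of these two groups, in this single pair only. Nothing available gives a reason for the fall.

Open, on these data alone, is whether a carboxylic acid or a dimethylamino group at this place would read nearer to compound 1 or to compound 3. Also open, as far as these compounds go, is whether the step keeps its size in cell lines other than this one.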